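Dimethoxyphenyl Replaces Fluorophenyl on the Thiazole Head Group

The source may hold more compounds than are shown below. What is called first, only, known or untested is meant among the compounds shown, and "the series" means these compounds.

Measured compounds: compound 1 `Cc1nc(-c2ccccc2)sc1COc1ccc2c(c1)OCC2CC(=O)O`, 54.8%; compound 2 `Cc1nc(-c2cc3ccccc3o2)sc1COc1ccc2c(c1)OCC2CC(=O)O`, 14.8%; compound 3 `Cc1nc(-c2ccc(F)cc2)sc1COc1ccc2c(c1)OCC2CC(=O)O`, 61.6%.

In a functional assay on CHO cells for agonist activity at Free fatty acid receptor 1 (Homo sapiens), read by FLIPR and calcium flux, tested at 100 nM (on this read-out lower numbers stand for a weaker effect and higher numbers for a stronger effect at the one concentration tested), compound 3 gives the highest of the three numbers; compound 1 sits within the scatter of it, while compound 2 lies far lower. Compound 4 `COc1cc(OC)cc(-c2nc(C)c(COc3ccc4c(c3)OCC4CC(=O)O)s2)c1` differs from compound 3 by 3,5-dimethoxyphenyl in place of 4-fluorophenyl on an aromatic carbon. Among the compounds with values here, the steps that bear on this are a number 6.8 percentage points higher from compound 1 to compound 3 (within the scatter), a small change on the same six-membered ring, and a number 46.8 percentage points higher from compound 2 to compound 3 (beyond the scatter) together with a number 40 percentage points lower from compound 1 to compound 2 (beyond the scatter), where the large loss came only with the 1-benzofuran-2-yl group. Compound 4 keeps a single six-membered carbon ring, so a step of modest size, if any, is expected, a number 16.6 percentage points lower from compound 3 to compound 4 (beyond the scatter). Compound 4 is estimated at 45%, with a range of 20% to 65%.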

Compound 4, a percentage reported as activity, at one concentration (the size of the read-out at that concentration, not a potency): 17.5%
Compound 4: the middle estimate sits 27.5 percentage points above what was measured, outside the stated range (below it).
By their numbers in this assay, from the lowest: compounds 2 and 4 (each within the scatter of the next); then compounds 1 and 3 (each within the scatter of the next).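

In this assay, keeping a single six-membered aromatic carbon ring at this aromatic carbon does not by itself preserve the read-out: the 3,5-dimethoxyphenyl group gives a number 44.1 percentage points lower from compound 3 to compound 4 (beyond the scatter) and a number 37.3 percentage points lower from compound 1 to compound 4 (beyond the scatter). A large loss at this position is thus no longer confined to 1-benzofuran-2-yl, since a number 2.7 percentage points higher from compound 2 to compound 4 (within the scatter) leaves those two compounds within the scatter of each other. Nothing available accounts for this loss. Going by these compounds, it remains open whether a single methoxy group on the phenyl ring would carry the same loss, and how hydroxy or amino groups in place of the methoxy groups would behave.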